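Isatin thiosemicarbazones: from benzyl to 3-chlorophenyl

The source may report more compounds than this note shows. Statements on the series, on what has been measured and on what is new or still open speak of the compounds shown alone.

Compound 1 (`O=C1Nc2ccccc2/C1=N/NC(=S)Nc1ccc2c(c1)CCC2`) gives 5800 nM
Compound 2 (`O=C1Nc2ccccc2/C1=N/NC(=S)NCc1ccccc1`) gives 11700 nM

Both values come from a functional assay on KB 3-1 cells (Homo sapiens) for cytotoxicity, read by MTT assay, with a stated time of 72 h (on this read-out higher numbers stand for weaker inhibition and lower numbers for stronger inhibition), and lie within the usual scatter of each other, so compound 2 cannot be separated from compound 1 on these numbers. Among the compounds with values here, no pair of measured compounds differing in one place is available, which leaves no direct guide to the size of the next step.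

Compound 3 (`O=C1Nc2ccccc2/C1=N/NC(=S)Nc1cccc(Cl)c1`) has not yet been measured. It keeps the core of compound 2 and carries 3-chlorophenyl in place of benzyl on an amide-type nitrogen. With compound 1 at 5800 nM and compound 2 at 11700 nM as the only reference points, a large change seems unlikely. A modest move toward a lower number in this assay is expected, and it may not clear the scatter. The estimated change is a 2.0-fold lower number from compound 2 to compound 3 (0.29 log units; within the scatter) and remains an expectation until the measurement is made. Compound 3 is expected at 6000 nM in this assay (estimated range 2000 nM to 16000 nM).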

Compound 3, half-maximal inhibitory concentration: 1870 nM
For compound 3 the middle estimate is 3.2-fold (0.51 log units) above the measured one; the measured number lies below the stated range.
By their numbers in this assay, from the lowest: compound 3; then compounds 1 and 2 (each within the scatter of the next).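

In this assay, within the data shown here, the change of benzyl to 3-chlorophenyl on the amide-type nitrogen gives the first step in this set that can be read directly, a 6.3-fold lower number from compound 2 to compound 3 (0.80 log units; beyond the scatter), and it lies beyond the scatter, whereas compound 1 and compound 2 could not be separated. This shows that the number responds to the group at this nitrogen, even though the two groups match in what is counted: 7 heavy atoms each, one six-membered aromatic ring of carbon only, and no hydrogen-bond donors or acceptors. Nothing measured here explains why the number falls with this exchange.

The single step joins two differences, the loss of the benzyl carbon link and the arrival of chlorine, so the compounds shown leave open which of them carries the change. Among these compounds, a plain phenyl group at this nitrogen would bear on that question, and a bromophenyl or methoxyphenyl group would bear on whether chlorine itself matters, while the step so far rests on one pair in one cell line.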